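Flavone-linked benzoxazines: removing one bromo substituent

The source may hold more compounds than are shown below. What is called first, only, known or untested is meant among the compounds shown, and "the series" means these compounds.

Compound 2, `O=c1cc(-c2ccccc2)oc2ccc(N3COc4c(Br)cc(Br)cc4C3)cc12`: 13.6%
Compound 3, `O=c1cc(-c2ccccc2)oc2cc(N3COc4c(Cl)cc(Cl)cc4C3)ccc12`: 11.8%
Compound 1, `O=c1cc(-c2ccccc2)oc2cc(N3COc4c(cccc4[N+](=O)[O-])C3)ccc12`: 1.96%

The three measured compounds share a core in which a phenyl-bearing chromenone carries a fused benzoxazine ring through nitrogen. In a functional assay on MCF7 cells (Homo sapiens) for inhibition, read by MTT assay, with a stated time of 48 h, tested at 15 ug/mL (a higher number here means more inhibition of growth at the concentration tested, a lower number less inhibition of growth), compound 2 gives the highest of the three numbers, but its gap to compound 3 lies within the scatter, so the two cannot be ordered; only compound 1 stands clearly lower, beyond the scatter. All three numbers are low.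

Compound 4, `O=c1cc(-c2ccccc2)oc2ccc(N3COc4c(Br)cccc4C3)cc12`, has not yet been measured. It differs from compound 2 in one place: hydrogen in place of bromo on an aromatic carbon. Going by the values given here, no pair of measured compounds differs in one place, so no measured step guides the size of this change. Given the narrow spread of the measured values, she expects the step from compound 2 to compound 4 to be small in this assay, a number 4.6 percentage points lower from compound 2 to compound 4 (within the scatter), if anything a slight decrease, and not beyond the scatter. Compound 4 is therefore estimated at 9%, within a range of 0% to 20%.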

Compound 4, percent growth inhibition at one concentration: 37.8%
Beside the measured number, compound 4's estimate is 28.8 percentage points below it; the whole stated range lies below it.
By their numbers in this assay, from the lowest: compounds 1, 3 and 2 (each within the scatter of the next, the first and the last beyond it); then compound 4.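

In this assay, going by these compounds alone, hydrogen in place of bromo on this aromatic carbon gives a number 24.2 percentage points higher from compound 2 to compound 4 (beyond the scatter), so a change in one place can move the number by more than the scatter, something the earlier compounds, none of them differing in one place, could not show. This bromo, meta to the remaining bromo group and para to a fused ring, is therefore not needed for the growth inhibition seen here, and its loss raises the number rather than lowering it. Nothing measured here accounts for the rise.

As far as these compounds go, whether the rise is specific to hydrogen on this carbon, or would also appear with a fluoro group, a methoxy group or an amine there, remains open. Also open, from the compounds shown here alone, is what would happen if the remaining bromo were replaced by hydrogen as well.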